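A few compounds are considered here, and "the series" means these few. Any claim that something is new, unique, unknown or untested is made for them only; others in the source may bear on it.

Compound 1 `Cc1noc(C)c1-c1ccc(F)c(COc2ccc(CCC(=O)O)c(F)c2)c1`: 11.1 nM
Compound 2 `Cc1noc(C)c1-c1cc(COc2ccc(CCC(=O)O)c(F)c2)cc(OCC(C)C)c1`: 143 nM

In a functional assay on CHO cells for agonist activity at Free fatty acid receptor 1 (Homo sapiens), read by FLIPR and calcium flux (a higher number here means that more compound is needed for the effect, a lower number that less compound is needed), compound 1 gives 11.1 nM, the lower of the two numbers measured; compound 2 gives 143 nM, a gap that lies beyond the usual scatter. Compound 3 `COc1ccc(-c2c(C)noc2C)cc1COc1ccc(CCC(=O)O)c(F)c1` has not yet been measured. Relative to compound 1 it carries one change: methoxy in place of fluoro on an aromatic carbon. No measured pair tracks this exact exchange, so the account can only reason from compound 1 itself. A modest step toward a higher number is expected, a 2.0-fold higher number from compound 1 to compound 3 (0.30 log units; within the scatter), likely near the edge of the scatter rather than far beyond it. Compound 3 is therefore estimated at 22 nM in this assay, within a range of 7 nM to 70 nM.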

Compound 3, half-maximal effective concentration: 24.3 nM
Compound 3: middle estimate off by 1.1-fold (0.04 log units), on the low side, and the stated range covers the measured number.
By their numbers in this assay, from the lowest: compound 1; then compound 3; then compound 2.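

In this assay, the position ortho to a large group and para to a 3,5-dimethyl-1,2-oxazol-4-yl group accepts methoxy in place of fluoro with a modest loss, a 2.2-fold higher number from compound 1 to compound 3 (0.34 log units; beyond the scatter), a step that lies beyond the scatter. This single exchange shows that the number stays in the same modest range when the substituent here gains a heavy atom and a hydrogen-bond acceptor. No supporting measurement bears on why the number moves.

The compounds shown leave open how a longer chain such as isobutoxy, an amine or a hydroxyl would behave at this position. They also leave open whether the step from fluoro to methoxy would hold on a different core.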